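From compound 2 to compound 3: another limit expected?

A few compounds are considered here, and "the series" means these few. Any claim that something is new, unique, unknown or untested is made for them only; others in the source may bear on it.

In a functional assay on cells (leukaemia cell line, Homo sapiens) for inhibition, read by sulforhodamine B assay, with a stated time of 48 h (on this read-out higher numbers stand for lower toxicity in this test and lower numbers for higher toxicity in this test), compound 1 `Cc1cc(Cl)ccc1NS(=O)(=O)c1ccc(-c2cnc(C3CC3)o2)cc1` gives > 100000 nM as a limit of the assay. Compound 2 `O=S(=O)(Nc1ccc(I)c(Cl)c1)c1ccc(-c2cnc(C3CC3)o2)cc1` gives > 100000 nM as a limit too and so has no number. Within the data shown here, the one measured step, a step that the two limits leave unreadable from compound 1 to compound 2 in size, offers no guide. Compound 3 `Cc1cc(F)cc(NS(=O)(=O)c2ccc(-c3cnc(C4CC4)o3)cc2)c1` differs from compound 2 by 3-fluoro-5-methylphenyl in place of 3-chloro-4-iodophenyl on a sulfonamide nitrogen in a single exchange on a sulfonamide nitrogen. Because the limit of > 100000 nM in this assay, at which 2 of the 2 values shown sit, describes compound 1 and compound 2 alike, no step beyond the scatter is expected in this assay in either direction. The expected change is a number no higher from compound 2 to compound 3 (the limit leaves the size open) in this estimate. Compound 3 is estimated at 100000 nM with an expected range from 50000 nM to 200000 nM and will probably be reported as a limit again.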

Compound 3, concentration lethal to 50% of the cells: 78100 nM
Compound 3: the middle estimate sits 1.3-fold (0.11 log units) above what was measured; measured number inside the range.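

In this assay, among these compounds, compound 3 gives 78100 nM, the only actual number among the three, so an exchange on a sulfonamide nitrogen can bring the reading inside the range of the assay. The change reads as an at least 1.2-fold lower number from compound 2 to compound 3 (0.10 log units; that floor lies within the scatter) and as an at least 1.2-fold lower number from compound 1 to compound 3 (0.10 log units; that floor lies within the scatter), and neither floor by itself shows a step beyond the scatter. The other two values remain limits: the limit of > 100000 nM in this assay, at which 2 of the 3 values shown sit.

The compounds shown leave open how far compound 1 and compound 2 truly lie from compound 3. They also leave open whether an amine or a carboxylic acid in place of the methyl of 3-fluoro-5-methylphenyl would move the number.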